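Reversing and lengthening the linker of compound 1

The source may report more compounds than this note shows. Statements on the series, on what has been measured and on what is new or still open speak of the compounds shown alone.

Compound 1 `CN(C)C(=O)c1cc2cnc(Nc3ccc(C(=O)NCCCN=C=S)cc3)nc2n1C1CCCC1` gives 32.9% in a functional assay on A549 cells (Homo sapiens) for inhibition, read by CCK-8 assay, with a stated time of 72 h, tested at 1 uM (on this read-out higher numbers stand for a stronger effect at the one concentration tested and lower numbers for a weaker effect), standing second of the three numbers: compound 3 `CN(C)C(=O)c1cc2cnc(Nc3ccc(C(=O)NCCCN=C=S)cc3F)nc2n1C1CCCC1` gives 16.7%, and compound 2 `CN(C)C(=O)c1cc2cnc(Nc3ccc(C(=O)NCCCCCCCN=C=S)cc3)nc2n1C1CCCC1` gives 73.7%. Compound 4 `CN(C)C(=O)c1cc2cnc(Nc3ccc(NC(=O)CCCCN=C=S)cc3)nc2n1C1CCCC1` has not been measured. It differs from compound 1 by a group of 10 heavy atoms (6 carbon, 2 nitrogen, 1 oxygen, 1 sulfur; no ring) in place of a group of 9 heavy atoms (5 carbon, 2 nitrogen, 1 oxygen, 1 sulfur; no ring), on an aromatic carbon, the entering group holding one heavy atom more. The step of a number 40.8 percentage points higher from compound 1 to compound 2 (beyond the scatter) shows that a longer chain carrying the isothiocyanate raised the read-out strongly; the step of a number 16.2 percentage points lower from compound 1 to compound 3 (beyond the scatter) changes a ring substituent and does not bear here. Because of a number 40.8 percentage points higher from compound 1 to compound 2 (beyond the scatter), a modest rise is expected for compound 4, smaller than that step since only one heavy atom is added, giving an expected a number 12.1 percentage points higher from compound 1 to compound 4 (beyond the scatter). Compound 4 is therefore estimated at 45%, between 22% and 68%.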

Compound 4, a percentage reported as inhibition, at one concentration (the size of the read-out at that concentration, not a potency): 38.2%
Beside the measured number, compound 4's estimate is 6.8 percentage points above it; the measured number falls inside the stated range.
By their numbers in this assay, from the lowest: compound 3; then compounds 1 and 4 (each within the scatter of the next); then compound 2.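

The swap at this aromatic carbon, which turns the amide around and enters a group holding one heavy atom more, gives a number 5.3 percentage points higher from compound 1 to compound 4 (within the scatter) in this assay. Compound 4 therefore cannot be told apart from compound 1, whereas the much longer chain gave a number 40.8 percentage points higher from compound 1 to compound 2 (beyond the scatter). No evidence at hand explains this result. From the compounds shown here alone, the turned amide and the added carbon come together here, so their separate contributions stay unknown. Also open, going by these compounds, is whether a longer chain on the turned amide would reach compound 2, and whether an amine could replace the isothiocyanate.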